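Hydroxy and Methoxy Thioureas on a Shared Indole-Bearing Core

The source may report more compounds than this note shows. Statements on the series, on what has been measured and on what is new or still open speak of the compounds shown alone.

Measured so far:
compound 1, `Oc1ccc(NC(=S)Nc2ccc3[nH]ccc3c2)cc1`, an ADME assay on cells for inhibition of Amine oxidase [flavin-containing] A (Homo sapiens), read by spectrophotometry; a lower number here means a stronger inhibitor, a higher number a weaker inhibitor: "not active" (no number reported)
compound 2, `COc1ccc(NC(=S)Nc2ccc3[nH]ccc3c2)cc1`, this assay: 36000 nM

Compound 1 carries a hydroxy group on the outer ring and returns no number in this assay; it is recorded as "not active" (no number reported). Compound 2 carries a methoxy group in the same position and in this assay gives 36000 nM, which is a weak half-maximal inhibitory concentration. For the measured compounds named here, the two values show only that neither compound inhibits strongly; no step between them is quantified, since compound 1 stands without a number.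

The next compound, compound 3, `COC(=O)c1cc(NC(=S)Nc2ccc3[nH]ccc3c2)ccc1O`, keeps the hydroxy group of compound 1 and adds one group: methoxycarbonyl in place of hydrogen on an aromatic carbon. The change is small in heavy atoms and introduces no ring.

Going by the values given here, with compound 1 giving no number, there is no measured step to lean on. The expectation is that compound 3 also stays weak in this assay, with a real chance of again returning no number rather than a value. Compound 3 is estimated at 50000 nM, within a range from 10000 nM to 300000 nM.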

Compound 3, half-maximal inhibitory concentration: "not active" (no number reported)
No number was reported for compound 3; the estimate stays without a comparison.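

With compound 1 at "not active" (no number reported) and compound 3 at "not active" (no number reported) in this assay no step can be read between them. No supporting data bear on this result. 

The compounds shown leave open whether, in this assay of a hydroxy compound on the shared core, methoxycarbonyl in place of hydrogen changes inhibition at all.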